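The source may report more compounds than this note shows. Statements on the series, on what has been measured and on what is new or still open speak of the compounds shown alone.

Measured so far in a functional assay for inhibition, tested at 80 ug/mL; a lower number here means a weaker effect, a higher number a stronger effect of the compound at the concentration tested:
compound 1 `Cc1cc(O)c(C(C)C)cc1-c1cc(-c2cccs2)c(C#N)c(=O)[nH]1` gives 63%
compound 2 `Cc1cc(O)c(C(C)C)cc1-c1cc(-c2ccc(N(C)C)cc2)c(C#N)c(=O)[nH]1` gives 66.5%

Compound 2 holds the higher of the two numbers, but the step of a number 3.5 percentage points higher from compound 1 to compound 2 (within the scatter) lies within the scatter, so no order between the two can be claimed. Compound 3 `Cc1cc(O)c(C(C)C)cc1-c1cc(-c2ccccc2[N+](=O)[O-])c(C#N)c(=O)[nH]1` differs from compound 2 by 2-nitrophenyl in place of 4-(dimethylamino)phenyl on an aromatic carbon. For the measured compounds named here, the one measured step that bears on such an exchange is a number 3.5 percentage points higher from compound 1 to compound 2 (within the scatter), and it stayed within the scatter. A step of the same kind is therefore expected here, none beyond the scatter, a number 3.5 percentage points lower from compound 2 to compound 3 (within the scatter). Compound 3 is estimated at 63%, from 45% to 80%.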

Compound 3, a percentage reported as inhibition, at one concentration (the size of the read-out at that concentration, not a potency): 35%
Estimate against measurement, compound 3: 28 percentage points above; the whole stated range lies above it.
By their numbers in this assay, from the lowest: compound 3; then compounds 1 and 2 (each within the scatter of the next).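

In this assay this position proves sensitive to the group it carries: 2-nitrophenyl gives a number 31.5 percentage points lower from compound 2 to compound 3 (beyond the scatter) and also a number 28 percentage points lower from compound 1 to compound 3 (beyond the scatter), whereas the exchange between thiophen-2-yl and 4-(dimethylamino)phenyl stayed within the scatter. Compound 3 therefore stands alone at the low end of the three. No data at hand account for this loss.

On these data alone, whether the loss follows the nitro group itself or its place on the phenyl ring stays open. A 4-nitrophenyl or an unsubstituted phenyl at this position would separate these readings.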